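Methyl for chloro on a quinoxaline dioxide chalcone

The compounds below may be only part of what the source reports. "The series", "measured", "known", "first", "only" and "open" are said of these compounds alone.

Measured compounds:
compound 1 `COc1ccc(/C=C/C(=O)c2c(C)[n+]([O-])c3ccccc3[n+]2[O-])cc1OC`: 19200 nM
compound 2 `Cc1c(C(=O)/C=C/c2ccc(Cl)cc2)[n+]([O-])c2ccccc2[n+]1[O-]`: 16000 nM

Of the compounds shown here, two sharing the same core have been measured in a functional assay on CCRF-CEM cells (Homo sapiens) for inhibition, with a stated time of 3 days; a lower number here means a stronger inhibitor, a higher number a weaker inhibitor. In this assay compound 1 gives 19200 nM, and in this assay compound 2 gives 16000 nM. Compound 2 thus has the lower of the two numbers, but the nearest number, that of compound 1, lies within the scatter of it, so the two values show no real separation.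

The next compound, compound 3 `Cc1ccc(/C=C/C(=O)c2c(C)[n+]([O-])c3ccccc3[n+]2[O-])cc1`, is derived from compound 2 by one change: methyl in place of chloro on an aromatic carbon, that is, a 4-chlorophenyl becoming a 4-methylphenyl. For the measured compounds named here, no pair of measured compounds differing in just one place is available, so there is no measured step to lean on. With both measured values so close together and the change confined to a single heavy atom, the step is expected to be small, or none beyond the scatter, with no direction favoured; the expected step in this assay is a 1.1-fold higher number from compound 2 to compound 3 (0.05 log units; within the scatter). Compound 3 is therefore estimated to give 18000 nM in this assay, within a range from 8000 nM to 40000 nM.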

Compound 3, half-maximal inhibitory concentration: 22400 nM
The estimate for compound 3 lay 1.2-fold (0.09 log units) below the measured number; low and high end bracket the measured number.
By their numbers in this assay, from the lowest: compounds 2, 1 and 3 (each within the scatter of the next).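

In this assay, for the compounds shown here, the only step measured so far is the exchange of the 4-chlorophenyl for the 4-methylphenyl, a 1.4-fold higher number from compound 2 to compound 3 (0.15 log units; within the scatter) and so methyl in place of chloro on an aromatic carbon, para to a large group, produces no separation between the two compounds. At this position, then, one heavy atom can stand in for another, with no ring, hydrogen-bond donor, hydrogen-bond acceptor or net charge entering or leaving, and the number stays within the scatter. No measurement at hand accounts for this result, so the step can be reported but not explained.

Going by these compounds, it remains open whether a group of another kind at the same position, such as an amine, a carboxylic acid or a longer chain, would shift the number beyond the scatter. This single step also cannot show whether methyl in place of chloro would read the same way on a different core or in a different assay.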